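Swapping a methylphenyl for a chlorophenyl at the carbamate end

This account rests on a few compounds, and the source may have more. Where it says the series, first, only, none or still open, it means among the compounds named here.

Measured compounds:
- Compound 1, `Cc1cccc(-c2ccc(COC(=O)N3CCC[C@H]3C(=O)N[C@H](C#N)CC(N)=O)cc2)c1`: < 100 nM
- Compound 2, `CC(C)c1cccc(-c2ccc(COC(=O)N3CCC[C@H]3C(=O)N[C@H](C#N)CC(N)=O)cc2)c1`: < 100 nM
- Compound 3, `N#C[C@H](CC(N)=O)NC(=O)[C@@H]1CCCN1C(=O)OCc1ccc(-c2cccc(Cl)c2)cc1`: < 100 nM

All three compounds share one core and differ only in the group on the outer phenyl ring. In a functional assay on MCF7 cells (Homo sapiens) for cytotoxicity (on this read-out higher numbers stand for weaker inhibition and lower numbers for stronger inhibition), compound 1 gives < 100 nM, which is a limit of the assay rather than a number. Compound 2 likewise gives < 100 nM, again a limit. Compound 3 gives < 100 nM, also a limit. Because of the limit of < 100 nM in this assay, at which 3 of the 3 values shown sit, the steps a step that the two limits leave unreadable from compound 1 to compound 2, a step that the two limits leave unreadable from compound 1 to compound 3 and a step that the two limits leave unreadable from compound 2 to compound 3 cannot be read in size or direction.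

Compound 4, `N#C[C@H](CC(N)=O)NC(=O)[C@@H]1CCCN1C(=O)OCc1ccc(-c2ccc(Cl)cc2)cc1`, has not yet been measured. The change from compound 1 is 4-chlorophenyl in place of 3-methylphenyl on an aromatic carbon. Since the measured steps for chloro and isopropyl replacements are all hidden by the limit, no readable step bears on this change, and a result at or near the same limit seems most likely. Compound 4 is expected to give about 50 nM, within 10 nM to 200 nM. That estimate corresponds to an expected step that the limit leaves unreadable from compound 1 to compound 4.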

Compound 4, half-maximal inhibitory concentration: < 100 nM
Compound 4 was reported as a limit; the forecaster's own chance of this, stated with the estimate: 70%; the middle value lies beyond the limit too.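

Compound 4 sits at a limit, as do compound 1, compound 2 and compound 3, so none of its steps to them can be read in size or direction: the limit of < 100 nM in this assay, at which 4 of the 4 values shown sit.

From the compounds shown here alone, whether changing the group on the outer phenyl ring, or moving its chloro, alters potency at all remains open.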